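Swapping the hydroxyphenyl for a methylphenyl on a shared core

The source may hold more compounds than are shown below. What is called first, only, known or untested is meant among the compounds shown, and "the series" means these compounds.

Measured so far:
compound 1 `COc1cc(-n2cnc3ccc(-c4cccc(C)c4C)cc32)cc(OC)c1OC`, 3040 nM
compound 2 `COc1ccccc1-c1ccc2ncn(-c3cc(OC)c(OC)c(OC)c3)c2c1`, 5050 nM
compound 3 `COc1cc(-n2cnc3ccc(-c4cccc(O)c4)cc32)cc(OC)c1OC`, 53 nM

All three share one core and differ only in the aryl group attached to it. In a functional assay on SGC-7901 cells (Homo sapiens) for antiproliferative activity, read by MTT assay, with a stated time of 72 h (on this read-out higher numbers stand for weaker inhibition and lower numbers for stronger inhibition), compound 3 gives the lowest number of the three; the nearest is compound 1 and the furthest is compound 2, and both steps toward compound 3 are large: a 57-fold lower number from compound 1 to compound 3 (1.76 log units; beyond the scatter) and a 95-fold lower number from compound 2 to compound 3 (1.98 log units; beyond the scatter). The step of a 1.7-fold higher number from compound 1 to compound 2 (0.22 log units; within the scatter) between the two weaker compounds is small.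

Compound 4 `COc1cc(-n2cnc3ccc(-c4ccc(C)cc4)cc32)cc(OC)c1OC` is not yet measured. Its change from compound 3 is 4-methylphenyl in place of 3-hydroxyphenyl on an aromatic carbon. Like the groups in compound 1 and compound 2, the entering 4-methylphenyl brings no hydrogen-bond donor and no hydrogen-bond acceptor. The two large steps above therefore bear on this change, and a large upward step in this assay is expected, roughly of the size seen from compound 1 or compound 2. For compound 4 the expected value is 2500 nM, in the range 500 nM to 10000 nM, which means an expected step of a 47-fold higher number from compound 3 to compound 4 (1.67 log units; beyond the scatter).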

Compound 4, half-maximal inhibitory concentration: 200 nM
For compound 4 the middle estimate is 13-fold (1.10 log units) above the measured one; measured number outside the range, below it.
By their numbers in this assay, from the lowest: compound 3; then compound 4; then compounds 1 and 2 (each within the scatter of the next).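

Removing the hydroxyl does not by itself bring the large loss seen with the earlier groups: the 4-methylphenyl brings no hydrogen-bond donor, yet the step is only modest (a 3.8-fold higher number from compound 3 to compound 4 (0.58 log units; beyond the scatter)). The choice of aryl group without a hydroxyl also matters at this position, since compound 4 stands well apart from both weaker compounds (a 25-fold lower number from compound 2 to compound 4 (1.40 log units; beyond the scatter); a 15-fold lower number from compound 1 to compound 4 (1.18 log units; beyond the scatter)). No measurement here explains why these aryl groups differ so much.

This change replaces the hydroxyl with a methyl and also moves the substituent, so the compounds shown do not separate those two effects. As far as these compounds go, it also remains open how an amine or a carboxylic acid on the same phenyl ring would compare with the 3-hydroxyphenyl of compound 3.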